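The source may hold more compounds than are shown below. What is called first, only, known or untested is meant among the compounds shown, and "the series" means these compounds.

Series notes. Compound 1 `COc1cc(OC)c2c(=O)cc(-c3ccc(OCCF)cc3)oc2c1`, compound 2 `COc1cc(OC)c2c(=O)cc(-c3ccc(OCCN)cc3)oc2c1` and compound 3 `COc1cc(OC)c2c(=O)cc(-c3ccc(OCC(O)CO)cc3)oc2c1` share one core and differ only in the group para to it on the aryl ring. In a functional assay (Homo sapiens) for antiproliferative activity, read by resazurin assay, with a stated time of 48 h, tested at 10 uM (on this read-out lower numbers stand for a weaker effect and higher numbers for a stronger effect at the one concentration tested), compound 2 gives 35%, the highest of the two numbers recorded; compound 3 gives 11%, and compound 1 is recorded as "not active" (no number reported). The step of a number 24 percentage points lower from compound 2 to compound 3 (beyond the scatter) shows that replacing the aminomethyl end of the chain by 1,2-dihydroxyethyl lowers the read-out. Compound 4 `COc1cc(OC)c2c(=O)cc(-c3ccc(Br)cc3)oc2c1` is not yet measured; it differs from compound 2 by bromo in place of 2-aminoethoxy on an aromatic carbon. Going by the values given here, the one comparable step, a number 24 percentage points lower from compound 2 to compound 3 (beyond the scatter), also removed the amine and gave a modest loss, so a fall beyond the scatter is expected for compound 4, a number 20 percentage points lower from compound 2 to compound 4 (beyond the scatter). Compound 4 is estimated at 15%, between 0% and 35%.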

Compound 4, a percentage reported as inhibition, at one concentration (the size of the read-out at that concentration, not a potency): 10%
Beside the measured number, compound 4's estimate is 5 percentage points above it, and the stated range covers the measured number.
By their numbers in this assay, from the lowest: compounds 4 and 3 (each within the scatter of the next); then compound 2.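

In this assay the change to bromo gives a number 25 percentage points lower from compound 2 to compound 4 (beyond the scatter) and the exchange of 2,3-dihydroxypropoxy for bromo gives a number 1 percentage points lower from compound 3 to compound 4 (within the scatter) on this aromatic carbon. Among the numbers at this position, only the 2-aminoethoxy chain of compound 2 stands apart, while a chain without the amine and a lone bromo read alike. Nothing available explains this difference. On these data alone, whether the amine alone or also its chain length sets the read-out stays open. As far as these compounds go, the outcome with a dimethylamino end, a longer aminoalkoxy chain or a carboxylic acid is also open.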